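The compounds below may be only part of what the source reports. "The series", "measured", "known", "first", "only" and "open" are said of these compounds alone.

Measured in a functional assay on HL-60 cells (Homo sapiens) for inhibition, read by MTT assay, with a stated time of 48 h, tested at 10 uM; a lower number here means less inhibition of growth, a higher number more inhibition of growth at the concentration tested:
compound 1 `Cc1cccc(/C=N/NC(=O)c2ccc(-c3ccccc3[N+](=O)[O-])o2)c1` gives 9.54%;
compound 2 `O=C(N/N=C/c1ccc(-c2ccc(F)cc2F)o1)c1ccccc1O` gives -9.5%.

Compound 2 stands lowest of the two numbers in this assay. Among the measured compounds shown here, its only neighbour is compound 1, whose value lies higher by an amount beyond the usual scatter of this kind of measurement. The two compounds differ in more than one place, so no single structural step can be read from that gap.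

Compound 3 `COc1ccccc1C(=O)N/N=C/c1ccc(-c2ccc(F)cc2F)o1` has not yet been measured in this assay. It differs from compound 2 in one place: methyl in place of hydrogen on an oxygen on an aromatic ring, which read one bond further out is hydroxy to methoxy, 2-hydroxyphenyl to 2-methoxyphenyl. For the measured compounds named here, no measured pair shows this change, so nothing is known about the size or direction of its step. The expected step is a number 6.5 percentage points higher from compound 2 to compound 3 (within the scatter), meaning no change beyond the scatter. Compound 3 is therefore estimated to give -3% in this assay, with a range from -20% to 15%.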

Compound 3, percent growth inhibition at one concentration: 7.77%
The estimate for compound 3 lay 10.8 percentage points below the measured number, and the stated range covers the measured number.
By their numbers in this assay, from the lowest: compound 2; then compounds 3 and 1 (each within the scatter of the next).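

In this assay, among the compounds shown here, methyl in place of hydrogen on an oxygen on an aromatic ring gives the first step that can be read at this position, a number 17.3 percentage points higher from compound 2 to compound 3 (beyond the scatter), a change from 2-hydroxyphenyl to 2-methoxyphenyl. This shows that the position is not silent to this small change: compound 2 gives -9.5%, while compound 3 gives 7.77%, so growth inhibition at the concentration tested rises. No measurement bears on the reason for this step.

The compounds shown leave open whether a longer chain on that oxygen, such as ethyl, would move the number further, or whether an amine in place of the hydroxy would do the same. They also leave open whether this change gives a similar step on a different core.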